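The compounds below may be only part of what the source reports. "The series", "measured", "known", "first", "only" and "open" are said of these compounds alone.

Going by the values given here, compound 1, with the structure `COc1ccc(-c2cc(-c3ccc(C4NC(=O)c5ccccc5N4)cc3)nc(N)n2)cc1`, is the only member of this small set for which a number exists: in an ADME assay on Vero cells (Chlorocebus sabaeus) for cytotoxicity, read by MTT assay, with a stated time of 72 h (on this read-out lower numbers stand for higher toxicity in this test and higher numbers for lower toxicity in this test), compound 1 gives 124000 nM. Compound 2, with the structure `COc1ccc(C(Nc2ccc(C3(C)NC(=O)c4ccccc4N3)cc2)c2nnnn2C2CCCCC2)cc1`, was run in the same series but in this assay compound 2 shows "not determined" (no result reported), so no comparison with it can be drawn. Compound 1 therefore stands alone on the numbers shown, with nothing above or below it to set a direction.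

Compound 3, with the structure `COc1cc(-c2cc(-c3ccc(C4NC(=O)c5ccccc5N4)cc3)nc(N)n2)cc(OC)c1OC`, differs from compound 1 in a single place, described as 3,4,5-trimethoxyphenyl in place of 4-methoxyphenyl on an aromatic carbon. Among the compounds with values here, no step between measured compounds exists to guide the size of the effect of this change in this assay. Within the data shown here, with only one value available, the expectation for compound 3 is that the step of a 1.4-fold lower number from compound 1 to compound 3 (0.14 log units; within the scatter) stays within the usual scatter or at most a little beyond it, in the direction of somewhat higher toxicity. On that basis compound 3 is estimated to give 90000 nM in this assay, within a range from 35000 nM to 230000 nM.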

Compound 3, half-maximal cytotoxic concentration: 85900 nM
Estimate against measurement, compound 3: 1.0-fold (0.02 log units) above; the range from low to high includes it.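

In this assay, 3,4,5-trimethoxyphenyl in place of 4-methoxyphenyl gives a 1.4-fold lower number from compound 1 to compound 3 (0.16 log units; within the scatter). Going by these compounds alone, this position, on an aromatic carbon of the six-membered aromatic ring with 2 nitrogen, therefore takes a group of 12 heavy atoms and 3 hydrogen-bond acceptors in place of one of 8 heavy atoms and 1 hydrogen-bond acceptor, and the read-out stays within the usual scatter, which the single value of compound 1 could not show. No measurement at hand bears on the cause of this result.

What the compounds shown leave open is whether a group of another kind on this aromatic carbon, such as a phenyl ring carrying a carboxylic acid, an amine or a longer alkoxy chain, would move the number in this assay beyond the scatter. They also leave open whether the same exchange would give a step of similar size on another core, and compound 2, with no result reported, offers no reading on that.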